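Dichlorophenyl in Place of the Carboxyphenyl Chain End

A few compounds are considered here, and "the series" means these few. Any claim that something is new, unique, unknown or untested is made for them only; others in the source may bear on it.

Compound 1 `COC(=O)c1ccccc1CCCCCCC(=O)c1ncc(-c2ccccn2)o1` and compound 2 `COC(=O)c1ccc(CCCCCCC(=O)c2ncc(-c3ccccn3)o2)cc1` share their core with compound 3 `O=C(O)c1cccc(CCCCCCC(=O)c2ncc(-c3ccccn3)o2)c1` and differ from it in the group at the far end of the chain. In an assay for inhibition of Fatty-acid amide hydrolase 1 (Rattus norvegicus) (a higher number here means a weaker inhibitor, a lower number a stronger inhibitor), compound 1 gives 1 nM, and compound 2 gives 1.5 nM. For compound 3 the assay returns only a limit, > 600 nM, and not a number, so compound 3 stands at the weak end of the values seen here, as the limit of > 600 nM in this assay, at which 1 of the 3 values shown sits, shows.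

Compound 4 `O=C(CCCCCCc1cccc(Cl)c1Cl)c1ncc(-c2ccccn2)o1` has not yet been measured. It differs from compound 3 in one place: 2,3-dichlorophenyl in place of 3-carboxyphenyl on a saturated chain carbon, six bonds along the chain from a carbonyl carbon. For the measured compounds named here, no pair of measured compounds covers this exact change, so the expectation leans on compound 1 at 1 nM and on compound 2 at 1.5 nM, both of which lack a hydrogen-bond donor at the chain end. A large step toward stronger inhibition is therefore expected, an at least 120-fold lower number from compound 3 to compound 4 (2.07 log units; beyond the scatter). Compound 4 is estimated at 5 nM, within a range from 1 nM to 40 nM.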

Compound 4, inhibition constant: 0.9 nM
Compound 4: middle estimate off by 5.6-fold (0.74 log units), on the high side; the measured number lies below the stated range.
By their numbers in this assay, from the lowest: compounds 4, 1 and 2 (each within the scatter of the next). At a limit, above all of these: compound 3.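

The change from 3-carboxyphenyl to 2,3-dichlorophenyl at this chain end gives an at least 660-fold lower number from compound 3 to compound 4 (2.82 log units; beyond the scatter) in this assay. The size of that step rests on a limit for compound 3 and not on a number: the limit of > 600 nM in this assay, at which 1 of the 4 values shown sits.

Compound 4 at 0.9 nM lies within the scatter of compound 1 at 1 nM and compound 2 at 1.5 nM, and its 2,3-dichlorophenyl group carries no hydrogen-bond donor or acceptor, so this position reaches such values without either one in the entering group.

The compounds shown leave open whether the chlorine atoms contribute anything, as a plain phenyl ring or a ring with a single chlorine would tell, and how an amine on the ring would fare. They also leave open how a shorter or longer chain would behave with 2,3-dichlorophenyl at its end.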